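Working notes on solubility in a small amide series

The source may hold more compounds than are shown below. What is called first, only, known or untested is meant among the compounds shown, and "the series" means these compounds.

Measured so far:
compound 1, `COc1ccc2nc(C)cc(OCC(=O)Nc3cc(C)cc(C)c3)c2c1`: 26000 nM
compound 2, `COc1ccc2nc(C)cc(OCC(=O)Nc3ccccc3)c2c1`: 63000 nM
compound 3, `COc1cccc(NC(=O)COc2cc(C)nc3ccc(OC)cc23)c1`: 35000 nM

In a physicochemical assay for solubility, in phosphate buffer, measured as kinetic solubility, with a stated time of 1 h, at pH 7.4 (on this read-out lower numbers stand for lower solubility and higher numbers for higher solubility), compound 1 gives 26000 nM. Compound 2 differs from compound 1 in the amide substituent, (3,5-dimethylphenyl in place of phenyl on an amide-type nitrogen), and the step is a 2.4-fold higher number from compound 1 to compound 2 (0.38 log units; beyond the scatter). Compound 3 stays close to compound 1: a 1.3-fold higher number from compound 1 to compound 3 (0.13 log units; within the scatter). Among the measured compounds shown here, the one methoxy change measured so far, (methoxy in place of hydrogen on an aromatic carbon), gave a 1.8-fold lower number from compound 2 to compound 3 (0.26 log units; within the scatter).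

Compound 4, `COc1ccc2nc(C)cc(OCC(=O)Nc3cc(C)c(OC)c(C)c3)c2c1`, has not yet been measured in this assay. It differs from compound 1 by methoxy in place of hydrogen on an aromatic carbon. This is the same kind of change as that between compound 2 and compound 3, not the same: there the methoxy sits meta to a large group, here it sits ortho to two methyl groups and para to a large group. For compound 4 the expected step is a 1.4-fold lower number from compound 1 to compound 4 (0.16 log units; within the scatter). That expectation rests on compound 2 and compound 3, whose step was a 1.8-fold lower number from compound 2 to compound 3 (0.26 log units; within the scatter), a single pair inside the scatter, so the direction is not secure. Compound 4 is estimated at 18000 nM in this assay, within 8000 nM to 40000 nM.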

Compound 4, solubility: 17000 nM
Compound 4: middle estimate off by 1.1-fold (0.02 log units), on the high side, and the stated range covers the measured number.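

In this assay, methoxy in place of hydrogen on an aromatic carbon gives a 1.5-fold lower number from compound 1 to compound 4 (0.18 log units; within the scatter), and the same kind of change on the other amide substituent gives a 1.8-fold lower number from compound 2 to compound 3 (0.26 log units; within the scatter). The two steps are printed in the same direction, but each lies within the scatter, so neither establishes a real shift, and a consistent effect of the change across the two substituents is not shown; all that carries over is that neither step goes beyond the scatter, even though the methoxy of compound 4 sits ortho to two methyl groups and para to a large group, and that of compound 3 sits in a different place. Nothing available here bears on the result.

The compounds shown leave open whether another group on this same aromatic carbon, such as an amine or a carboxylic acid, would give a step beyond the scatter. They also leave open what a longer chain in place of the methyl group on the shared core would do to the read-out.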